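The compounds below may be only part of what the source reports. "The series", "measured", "known", "first", "only" and "open" are said of these compounds alone.

Going by the values given here, compound 2 `COc1cc(N)c(Cl)cc1C(=O)CCC1CCN(CCNS(=O)(=O)c2cc(Br)ccc2Br)CC1` gives 16.3 nM in an assay on brain for displacement of a labelled ligand from 5-hydroxytryptamine receptor 4 (Cavia porcellus), with a stated time of 30 min, in the presence of a further agent that is not named here (on this read-out higher numbers stand for weaker inhibition and lower numbers for stronger inhibition), the highest of the two numbers so far; compound 1 `COc1cc(N)c(Cl)cc1C(=O)CCC1CCN(CCNS(=O)(=O)c2ccc(N)cc2)CC1` gives 1.97 nM. Among the compounds with values here, the one measured step, an 8.3-fold higher number from compound 1 to compound 2 (0.92 log units; beyond the scatter), came with 2,5-dibromophenyl in place of 4-aminophenyl on a sulfonyl sulfur. Compound 3 `COc1ccc(S(=O)(=O)NCCN2CCC(CCC(=O)c3cc(Cl)c(N)cc3OC)CC2)cc1` carries 4-methoxyphenyl in place of 2,5-dibromophenyl on a sulfonyl sulfur. This change undoes much of that step, and a lower number is expected for compound 3, a partial return toward compound 1 at 1.97 nM rather than a full one. The expected step is a 3.6-fold lower number from compound 2 to compound 3 (0.56 log units; beyond the scatter). The estimate for compound 3 is 4.5 nM, range 1.5 nM to 13 nM.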

Compound 3, inhibition constant: 12.3 nM
For compound 3 the middle estimate is 2.7-fold (0.44 log units) below the measured one; low and high end bracket the measured number.
By their numbers in this assay, from the lowest: compound 1; then compounds 3 and 2 (each within the scatter of the next).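

In (this assay), 4-methoxyphenyl and 2,5-dibromophenyl on the sulfonyl sulfur cannot be told apart (a 1.3-fold lower number from compound 2 to compound 3 (0.12 log units; within the scatter)), so dropping both bromines does not by itself recover the number of compound 1. Going by these compounds alone, the single change of methoxy in place of amino on an aromatic carbon spans a gap beyond the scatter (a 6.2-fold higher number from compound 1 to compound 3 (0.80 log units; beyond the scatter)), which sets the 4-aminophenyl of compound 1 apart from the other two aryl groups. Nothing available explains this difference.

Open, as far as these compounds go, is whether an acetamide or a hydroxyl in place of that amino would keep the number of compound 1, or whether only the free amine does.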